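Removing the (1-bromoethenyl)carbonyl group from compound 2

This account rests on a few compounds, and the source may have more. Where it says the series, first, only, none or still open, it means among the compounds named here.

In a functional assay on HeLa cells (Homo sapiens) for antiproliferative activity, with a stated time of 48 h (on this read-out higher numbers stand for weaker inhibition and lower numbers for stronger inhibition), compound 1 `C=C(Br)C(=O)Nc1ccc(/C=C/C(=O)c2ccc(Cl)c(Cl)c2)cc1` gives 3200 nM, compound 2 `C=C(Br)C(=O)Nc1ccc(/C=C/C(=O)c2ccc(Br)cc2)cc1` gives 1000 nM and compound 3 `C=C(Br)C(=O)Nc1ccc(/C=C/C(=O)c2ccc(OC)cc2)cc1` gives 1400 nM. Compound 2 stands level with compound 3 within the scatter, at a 1.4-fold higher number from compound 2 to compound 3 (0.15 log units; within the scatter), and clear of compound 1, at a 3.2-fold lower number from compound 1 to compound 2 (0.51 log units; beyond the scatter). The remaining step is a 2.3-fold lower number from compound 1 to compound 3 (0.36 log units; beyond the scatter).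

Compound 4 `Nc1ccc(/C=C/C(=O)c2ccc(Br)cc2)cc1` differs from compound 2 by hydrogen in place of (1-bromoethenyl)carbonyl on a nitrogen on an aromatic ring. All measured steps alter only the group on the carbonyl carbon, so none bears directly on this change, and the largest is modest. A larger move towards a higher number is expected, on judgement alone. The estimated step is a 12-fold higher number from compound 2 to compound 4 (1.08 log units; beyond the scatter). For compound 4 the expected value is 12000 nM, with an estimated range of 3000 nM to 50000 nM.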

Compound 4, half-maximal inhibitory concentration: 49000 nM
Beside the measured number, compound 4's estimate is 4.1-fold (0.61 log units) below it, and the stated range covers the measured number.
By their numbers in this assay, from the lowest: compounds 2 and 3 (each within the scatter of the next); then compound 1; then compound 4.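

Earlier steps changed only the group on the carbonyl carbon and stayed modest, while this first change at the nitrogen, in this assay, gives a 49-fold higher number from compound 2 to compound 4 (1.69 log units; beyond the scatter). For the 4-bromophenyl pair, the number therefore depends far more on the (1-bromoethenyl)carbonyl group than on any carbonyl-carbon change shown. No measurement at hand accounts for this step.

Which part of the departing group carries the step stays open; an acetyl or unbrominated propenoyl group on the nitrogen would help separate them. From the compounds shown here alone, whether the step holds with 4-methoxyphenyl or 3,4-dichlorophenyl on the carbonyl carbon also stays open.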